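A few compounds are considered here, and "the series" means these few. Any claim that something is new, unique, unknown or untested is made for them only; others in the source may bear on it.

Working notes on the series, read in a functional assay on Jurkat cells (Homo sapiens) for antiproliferative activity, read by MTT assay, with a stated time of 72 h; on this read-out lower numbers stand for stronger inhibition and higher numbers for weaker inhibition. Compound 1 (`COc1cc(-c2ncnn2-c2cccc(N)c2)cc(OC)c1OC`) gives > 10000 nM, which is a limit of the assay and not a number. Compound 2 (`COc1cc(-c2ncnn2-c2ccc(F)cc2)cc(OC)c1OC`) gives > 10000 nM, again a limit. Compound 3 (`COc1cc(-c2ncnn2-c2ccc(N)cc2)cc(OC)c1OC`) gives > 10000 nM, also a limit, so it has no readable position relative to the other two. All the data so far come down to the limit of > 10000 nM in this assay, at which 3 of the 3 values shown sit.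

The next change leads to compound 4 (`COc1ccc(-n2ncnc2-c2cc(OC)c(OC)c(OC)c2)cc1`): methoxy in place of amino on an aromatic carbon. In words, methoxy takes the place of amino on an aromatic carbon, para to a large group, turning 4-aminophenyl into 4-methoxyphenyl.

Going by the values given here, three measured steps bear on this change: a step that the two limits leave unreadable from compound 2 to compound 3, a step that the two limits leave unreadable from compound 1 to compound 3 and a step that the two limits leave unreadable from compound 1 to compound 2. The first changes the same place, and the other two change the same aryl group, yet none has a readable size. The series therefore gives no measured size or direction for a change at this place. No clear step is expected in this assay, and another limit is the most likely result. The expected step is an at least 1.1-fold lower number from compound 3 to compound 4 (0.04 log units; that floor lies within the scatter). For compound 4 the estimated value is 9000 nM, with an expected range from 500 nM to 20000 nM.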

Compound 4, half-maximal inhibitory concentration: 93 nM
Compound 4: middle estimate off by 97-fold (1.99 log units), on the high side, outside the stated range (below it).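

In this assay, going by these compounds alone, the aryl group on the aromatic nitrogen can decide the read-out, which the earlier compounds could not show, as their steps among themselves cannot be read. Methoxy on this aromatic carbon separates clearly from amino (an at least 100-fold lower number from compound 3 to compound 4 (2.03 log units; beyond the scatter)) and from fluoro (an at least 100-fold lower number from compound 2 to compound 4 (2.03 log units; beyond the scatter)), and 4-methoxyphenyl separates just as clearly from 3-aminophenyl (an at least 100-fold lower number from compound 1 to compound 4 (2.03 log units; beyond the scatter)). Within the data shown here, all three steps are floors on the true size, and within these four compounds the 4-methoxyphenyl group of compound 4 is the only aryl group that leaves the limit shared by the others: the limit of > 10000 nM in this assay, at which 3 of the 4 values shown sit.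

The compounds shown leave open whether this result needs methoxy itself or would also hold for another group on the same carbon, such as ethoxy, hydroxy or methyl. They also leave open whether the place on the ring matters for methoxy, as a 3-methoxyphenyl group is not among them, and how far the shared core can change while compound 4 keeps its value.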